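The source may report more compounds than this note shows. Statements on the series, on what has been measured and on what is new or still open speak of the compounds shown alone.

Measured so far:
compound 1, `CCc1nn(CCO)c(CC)c1Oc1cc(C)cc(C#N)c1`: 0.283 h
compound 2, `CCc1nn(CCN)c(CC)c1Oc1cc(C#N)cc(C#N)c1`: > 2 h

In an in vitro ADME assay on microsomes from liver (Homo sapiens) for metabolic stability (a higher number here means that the compound lasts longer, a lower number that the compound disappears faster), compound 1 gives 0.283 h, and this is the only plain number among the two results shown. For compound 2 the result in this assay is > 2 h, which is a limit of the assay and not a number. The result of compound 2 thus sits at the limit of > 2 h in this assay, at which 1 of the 2 values shown sits. For the measured compounds named here, compound 1 and compound 2 differ in more than one place, so no single step between them is set out; the two results show only that compound 1 stands at a short half-life while compound 2 stands at a limit.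

Compound 3, `CCc1nn(CCO)c(CC)c1Oc1cccc(C#N)c1`, has not yet been measured in this assay. Compared with compound 1 the change is hydrogen in place of methyl on an aromatic carbon. Going by the values given here, no measured step of this kind is at hand, so the expectation is a small step in this assay, at most around the scatter, with a slight lean towards a longer half-life. For compound 3 the estimate in this assay is 0.4 h, within 0.2 h to 0.8 h, which is the step of a 1.4-fold higher number from compound 1 to compound 3 (0.15 log units; within the scatter) expected from compound 1.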

Compound 3, half-life in the Homo sapiens assay: 0.45 h
For compound 3 the middle estimate is 1.1-fold (0.05 log units) below the measured one; the measured number falls inside the stated range.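

In the Homo sapiens assay, the step for hydrogen in place of methyl on this aromatic carbon, meta to a cyano group, is a 1.6-fold higher number from compound 1 to compound 3 (0.20 log units; within the scatter), so the half-life of this pair cannot be told apart at this position. In a physicochemical assay for lipophilicity (on this read-out higher numbers stand for higher lipophilicity and lower numbers for lower lipophilicity), compound 1 gives 3.2 and compound 3 gives 2.7. In the physicochemical assay the same change is a number 0.50 log units lower from compound 1 to compound 3 (beyond the scatter), so for this one change the two read-outs part: one step lies beyond the scatter and the other within it.

In the Homo sapiens assay compound 2 gives > 2 h, which is a limit of the assay, and compound 2 differs from compound 1 and from compound 3 in more than one place, so its result cannot be tied to any single group. From the compounds shown here alone, what a methoxy group or a chlorine atom on this aromatic carbon would do to either read-out stays open, as does how the second nitrile and the amine of compound 2 would each count alone.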